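Aryl replacement on the shared core: compound 3

The source may hold more compounds than are shown below. What is called first, only, known or untested is meant among the compounds shown, and "the series" means these compounds.

Two compounds have numbers in a functional assay on SW-620 cells (Homo sapiens) for cytotoxicity; on this read-out lower numbers stand for stronger inhibition of growth and higher numbers for weaker inhibition of growth:
compound 1, `COc1ccc(C2=C(c3ccc(SC)cc3)CC3CCCN3C2=O)cc1Br`, gives 5000 nM
compound 2, `CSc1ccc(C2=C(c3ccc(C)c(C)c3)C(=O)N3CCCC3C2)cc1`, gives 700 nM

Among the compounds with values here, compound 1 holds the highest of the two numbers in this assay; the only measured step, a 7.1-fold lower number from compound 1 to compound 2 (0.85 log units; beyond the scatter), runs toward a lower number and lies beyond the scatter.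

Compound 3, `CSc1ccc(C2=C(c3ccc(F)cc3)C(=O)N3CCCC3C2)cc1`, is not yet measured. It differs from compound 1 in one place: 4-fluorophenyl in place of 3-bromo-4-methoxyphenyl on a double-bonded ring carbon.

Within the data shown here, the one step that bears on this change is a 7.1-fold lower number from compound 1 to compound 2 (0.85 log units; beyond the scatter), which also swaps the 3-bromo-4-methoxyphenyl group on the same double-bonded ring carbon, there for 3,4-dimethylphenyl. That step gave a clear move toward a lower number. Among the measured compounds shown here, the group entering in compound 3 is 4-fluorophenyl, not the same group, so the size of that step cannot simply be carried over; the direction is the only guide, and no second step exists to check it.

Compound 3 is therefore expected to land below compound 1, at an estimated 1500 nM, range 500 nM to 5000 nM, which means an expected step of a 3.3-fold lower number from compound 1 to compound 3 (0.52 log units; beyond the scatter).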

Compound 3, concentration for 50% growth inhibition: 500 nM
For compound 3 the middle estimate is 3.0-fold (0.48 log units) above the measured one, and the stated range covers the measured number.
By their numbers in this assay, from the lowest: compounds 3 and 2 (each within the scatter of the next); then compound 1.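

In this assay the change to 4-fluorophenyl on the double-bonded ring carbon gives a 10-fold lower number from compound 1 to compound 3 (1.00 log units; beyond the scatter) and thus adds a second replacement of 3-bromo-4-methoxyphenyl that runs the same way as a 7.1-fold lower number from compound 1 to compound 2 (0.85 log units; beyond the scatter) at this position, so the direction no longer rests on a single step. The two replacement groups are not separated in this read-out: a 1.4-fold lower number from compound 2 to compound 3 (0.15 log units; within the scatter) stays within the scatter, although one group carries a lone fluorine and the other two methyl groups. No measurement is available here to explain the shift seen on leaving 3-bromo-4-methoxyphenyl.

Still open, going by these compounds, is whether the bromine, the methoxy group or the two together set the higher number of compound 1, since they leave together in both steps and neither is seen alone at this position. Also open, on these data alone, is how far this position tolerates groups of another kind, such as a phenyl ring bearing an amine or a carboxylic acid, and whether the 4-(methylsulfanyl)phenyl group, common to all three compounds, contributes to the numbers seen.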